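This account rests on a few compounds, and the source may have more. Where it says the series, first, only, none or still open, it means among the compounds named here.

Measured so far in a functional assay on SW-620 cells (Homo sapiens) for inhibition, read by MTT assay, with a stated time of 72 h; a lower number here means a stronger inhibitor, a higher number a weaker inhibitor:
Compound 1, `CCN1CCN(Cc2c(OC)cc(Oc3cccc(Nc4ccccc4)c3)cc2OC)CC1`: > 20000 nM, a limit of the assay rather than a number.
Compound 2, `COc1cc(Oc2cccc(Nc3ccccc3)c2)cc(OC)c1CNCc1ccc(C)cc1`: 11800 nM.
Compound 3, `COc1cc(Oc2cccc(Nc3ccccc3)c2)cc(OC)c1CNCc1ccccc1`: 7490 nM.

Compound 1 stands only at a limit in this assay; of the three values shown, its is the one sitting at the limit of > 20000 nM in this assay, at which 1 of the 3 values shown sits. Compound 4, `COc1cc(Oc2cccc(Nc3ccccc3)c2)cc(OC)c1CN(C)C`, differs from compound 1 in one place: dimethylamino in place of 4-ethylpiperazin-1-yl on a saturated chain carbon bound to an aromatic carbon. The measured steps that bear on this change are an at least 1.6-fold lower number from compound 1 to compound 2 (0.22 log units; that floor lies within the scatter) and an at least 2.6-fold lower number from compound 1 to compound 3 (0.42 log units; beyond the scatter), both of which replace the same leaving group with a benzyl-type amine; the step of a 1.6-fold lower number from compound 2 to compound 3 (0.20 log units; within the scatter) is within the scatter. The dimethylamino group entering in compound 4 has no ring and no benzyl part, so these two steps give only loose guidance, and the nearest measured point, compound 1, sits at the limit. The expectation for compound 4 is therefore a number at or close to that limit, a step that the limit leaves unreadable from compound 1 to compound 4, with a real chance that another limit is reported. Compound 4 is estimated at 25000 nM in this assay, with a range from 10000 nM to 60000 nM.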

Compound 4, half-maximal inhibitory concentration: > 20000 nM
Compound 4: only a limit was reported (the forecaster's own chance of this, stated with the estimate: 60%); the middle value is on the limit's open side.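

In this assay compound 4 gives > 20000 nM, a limit of the assay and not a number; compound 1 also stands at a limit, so the step between these two cannot be read. On the saturated chain carbon bound to an aromatic carbon, dimethylamino in place of benzylamino gives an at least 2.6-fold higher number from compound 3 to compound 4 (0.42 log units; beyond the scatter), while dimethylamino in place of (4-methylbenzyl)amino gives an at least 1.6-fold higher number from compound 2 to compound 4 (0.22 log units; that floor lies within the scatter), so only the first comparison clearly separates compound 4 from a benzyl-type amine. The two amines without a benzyl part, the ringed 4-ethylpiperazin-1-yl and the open-chain dimethylamino, now share one reading: the limit of > 20000 nM in this assay, at which 2 of the 4 values shown sit.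

Still open, from the compounds shown here alone, is whether the benzyl ring or the amine hydrogen accounts for the separation from compound 3. Methylamino and N-methylbenzylamino on the same carbon would pull these two apart.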